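Exchanging a Methoxyphenoxypropyl Chain for a Difluorophenyl Carbamate

This account rests on a few compounds, and the source may have more. Where it says the series, first, only, none or still open, it means among the compounds named here.

Compound 1, `COc1ccc(C(=O)NCCCOc2cc(=O)n(CCCO)c3c2CC(C/C=C(\C)CCC=C(C)C)C(C)(C)C3)cc1`: 45.7%
Compound 2, `COc1ccc(OCCCOc2cc(=O)n(CCCO)c3c2CC(C/C=C(\C)CCC=C(C)C)C(C)(C)C3)cc1`: 20%

In a functional assay on PANC-1 cells (Homo sapiens) for inhibition, read by MTT assay, with a stated time of 24 h, tested at 10 uM (a lower number here means less inhibition, a higher number more inhibition at the concentration tested (going by the name of the read-out)), compound 2 gives 20%, the lowest of the two numbers. Going by the values given here, the only measured step, a number 25.7 percentage points lower from compound 1 to compound 2 (beyond the scatter), lies beyond the scatter. Compound 3, `CC(C)=CCC/C(C)=C/CC1Cc2c(OC(=O)Nc3ccc(F)cc3F)cc(=O)n(CCCO)c2CC1(C)C`, differs from compound 2 by (2,4-difluorophenyl)carbamoyl in place of 3-(4-methoxyphenoxy)propyl on an oxygen on an aromatic ring. Among the compounds with values here, that earlier step altered a group within the chain that compound 3 loses altogether, so it bears only loosely on this change, and no measured step tests a carbamoyl group. A modest rise is expected, a number 15 percentage points higher from compound 2 to compound 3 (beyond the scatter), with wide uncertainty. Compound 3 is therefore estimated at 35%, between 10% and 60%.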

Compound 3, a percentage reported as inhibition, at one concentration (the size of the read-out at that concentration, not a potency): 33.7%
For compound 3 the middle estimate is 1.3 percentage points above the measured one; the range from low to high includes it.
By their numbers in this assay, from the lowest: compound 2; then compound 3; then compound 1.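

Replacing the whole group on this oxygen, not just a part within the chain, gives a change beyond the usual scatter in this assay: a number 13.7 percentage points higher from compound 2 to compound 3 (beyond the scatter). The swap alters the linker and the ring substituents together, so this single step cannot assign the rise to either one. Nothing available explains the rise.

As far as these compounds go, what remains open is whether the two fluorines matter, which a plain phenyl carbamate would test. Also open, from the compounds shown here alone, is how a simple amine or a carboxylic acid at this oxygen-linked position would read.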